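This account rests on a few compounds, and the source may have more. Where it says the series, first, only, none or still open, it means among the compounds named here.

Measured so far in a functional assay on BJAB cells (Homo sapiens) for antiproliferative activity, with a stated time of 4 days; a higher number here means that more compound is needed for the effect, a lower number that less compound is needed:
Compound 1 `Cc1ccc(-c2c(C)nn(-c3nc(-c4ccc(Cl)c(Cl)c4)c(SC(C)C)s3)c2C(=O)O)cc1` gives 3800 nM.
Compound 2 `COc1cc(-c2c(C)nn(-c3nc(-c4ccc(Cl)c(Cl)c4)c(SC(C)C)s3)c2C(=O)O)cc(C(F)(F)F)c1` gives 1380 nM.

Among the measured compounds shown here, of these two numbers, compound 2 has the lower one; the only other compound, compound 1, sits at a higher number, and that gap is beyond the scatter. For the measured compounds named here, the single measured step, a 2.8-fold lower number from compound 1 to compound 2 (0.44 log units; beyond the scatter), describes the swap of the 4-methylphenyl for the 3-methoxy-5-(trifluoromethyl)phenyl.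

Compound 3 `Cc1ccccc1-c1c(C)nn(-c2nc(-c3ccc(Cl)c(Cl)c3)c(SC(C)C)s2)c1C(=O)O` is not yet measured. It differs from compound 2 in one place: 2-methylphenyl in place of 3-methoxy-5-(trifluoromethyl)phenyl on an aromatic carbon. This change removes the 3-methoxy-5-(trifluoromethyl)phenyl that entered in the measured step and puts a methylphenyl back, though now as 2-methylphenyl rather than 4-methylphenyl. Going by the values given here, only that one step bears on the question; it was modest but beyond the scatter. A step back toward the number of compound 1 is therefore expected, with the caution that nothing measured tells whether 2-methylphenyl and 4-methylphenyl behave alike. The expected step for compound 3 is a 2.2-fold higher number from compound 2 to compound 3 (0.34 log units; beyond the scatter). The estimate for compound 3 in this assay is 3000 nM, with a range from 1200 nM to 8000 nM.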

Compound 3, half-maximal effective concentration: 5500 nM
Estimate against measurement, compound 3: 1.8-fold (0.26 log units) below, within the range that was stated.
By their numbers in this assay, from the lowest: compound 2; then compounds 1 and 3 (each within the scatter of the next).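

In this assay, 2-methylphenyl in place of 3-methoxy-5-(trifluoromethyl)phenyl gives a 4.0-fold higher number from compound 2 to compound 3 (0.60 log units; beyond the scatter) and this is the larger of the two steps away from compound 2, so its lower number now stands against two different methylphenyl groups on this aromatic carbon of the five-membered ring, not just one. 2-methylphenyl in place of 4-methylphenyl gives a 1.4-fold higher number from compound 1 to compound 3 (0.16 log units; within the scatter) and so moving the methyl around the phenyl ring makes no readable difference in these two compounds, which leaves the real change in the number tied to the swap of the whole substituted phenyl. Nothing measured here accounts for these differences.

On these data alone, the methoxy and the trifluoromethyl enter and leave together, and the swap also changes the group from 12 heavy atoms to 7, so it remains open whether either group alone would give the lower number of compound 2. Also open, as far as these compounds go, is how this aromatic carbon would respond to a phenyl carrying something quite different, such as an amine or a carboxylic acid.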